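Shifting a Fluorine on a Weakly Inhibiting Sulfonamide

This account rests on a few compounds, and the source may have more. Where it says the series, first, only, none or still open, it means among the compounds named here.

Measured so far:
compound 1 `O=S(=O)(Nc1ccc(-c2nc3ccccc3o2)cc1)c1cccc(F)c1`: > 63000 nM
compound 2 `O=S(=O)(Nc1ccc(-c2nc3ccccc3o2)cc1)c1ccc(Cl)c(C(F)(F)F)c1`: > 63000 nM

In an assay on isolated protein for inhibition of malate dehydrogenase, mitochondrial (Sus scrofa), with stated times of 45 min and 30 min (a higher number here means a weaker inhibitor, a lower number a stronger inhibitor), compound 1 gives > 63000 nM, which is a limit of the assay rather than a number. Compound 2 likewise gives > 63000 nM in this assay, again a limit. Both values therefore sit at the limit of > 63000 nM in this assay, at which 2 of the 2 values shown sit, so compound 1 stands at the weak edge of what can be measured, with no finite number among the compounds seen so far to rank it against.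

Compound 3 `O=S(=O)(Nc1ccc(-c2nc3ccccc3o2)cc1)c1ccccc1F` differs from compound 1 only by 2-fluorophenyl in place of 3-fluorophenyl on a sulfonyl sulfur. Going by the values given here, no measured step between two compounds exists here to guide an expectation. Given that compound 1 gives > 63000 nM, the change from compound 1 to compound 3 is expected to leave things within the scatter, a step that the limit leaves unreadable from compound 1 to compound 3. Compound 3 is thus estimated at 80000 nM, between 30000 nM and 200000 nM, and most likely again as a limit.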

Compound 3, half-maximal inhibitory concentration: > 63000 nM
Compound 3 was reported as a limit; the forecaster's own chance of this, stated with the estimate: 80%; the middle value lies beyond the limit too.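

Moving the fluorine from 3-fluorophenyl in compound 1 to 2-fluorophenyl in compound 3 gives no step that can be read, because both results are limits and not numbers: the limit of > 63000 nM in this assay, at which 3 of the 3 values shown sit.

The compounds shown leave open whether the place of the fluorine affects inhibition at all, and how weak each compound truly is.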